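Replacing a Butyl(methyl)amino Group with an Acetoxypiperidine Ring

This account rests on a few compounds, and the source may have more. Where it says the series, first, only, none or still open, it means among the compounds named here.

Of the compounds shown here, three sharing a common core have been measured so far. Compound 1 `CC(C(=O)NCc1ccc(C(F)(F)F)nc1NCC1CCN(C(=O)OC(C)(C)C)CC1)c1ccc(NS(C)(=O)=O)c(F)c1` gives 1140 nM in a functional assay on CHO-K1 cells for antagonist activity at transient receptor potential cation channel subfamily V member 1 (Homo sapiens), read by FLIPR; a higher number here means a weaker inhibitor, a lower number a stronger inhibitor. Compound 2 `CCCCN(C)c1nc(C(F)(F)F)ccc1CNC(=O)C(C)c1ccc(NS(C)(=O)=O)c(F)c1` gives 21.3 nM, the lowest number of the three, while compound 3 `C[C@H](C(=O)NCc1ccc(C(F)(F)F)nc1N1CC[C@@H](OCc2ccccc2)C1)c1ccc(NS(C)(=O)=O)c(F)c1` gives 50 nM. Compound 4 `CC(=O)OC1CCN(c2nc(C(F)(F)F)ccc2CNC(=O)C(C)c2ccc(NS(C)(=O)=O)c(F)c2)CC1` has not yet been tested. It differs from compound 2 in one place: 4-acetoxypiperidin-1-yl in place of butyl(methyl)amino on an aromatic carbon. Compound 3 shows that a ring-bound nitrogen on that aromatic carbon can still give a low number, whereas compound 1 shows that a bulkier substituted group there can weaken inhibition markedly. Compound 4 is therefore expected to land modestly above compound 2, the step from compound 2 to compound 4 estimated as a 2.8-fold higher number from compound 2 to compound 4 (0.45 log units; beyond the scatter). The expected value for compound 4 is 60 nM, within a range from 20 nM to 200 nM.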

Compound 4, half-maximal inhibitory concentration: 139 nM
Beside the measured number, compound 4's estimate is 2.3-fold (0.36 log units) below it; the range from low to high includes it.
By their numbers in this assay, from the lowest: compound 2; then compound 3; then compound 4; then compound 1.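

Placing 4-acetoxypiperidin-1-yl on this aromatic carbon, next to the ring nitrogen, in place of butyl(methyl)amino gives a 6.5-fold higher number from compound 2 to compound 4 (0.81 log units; beyond the scatter) in this assay, so a ring bearing an ester at this position weakens inhibition, although compound 4 still reads 139 nM. The swap changes the ring and the acetoxy group at once, so this single step cannot separate their contributions. Nothing measured here explains the loss.

As far as these compounds go, whether an unsubstituted piperidine or a 4-hydroxypiperidine would come closer to compound 2 remains open. So does the effect of a morpholine at this position.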